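A few compounds are considered here, and "the series" means these few. Any claim that something is new, unique, unknown or untested is made for them only; others in the source may bear on it.

Working notes on the series, read in a functional assay on the whole organism for antagonist activity, with Mus musculus as the target; a higher number here means that more compound is needed for the effect, a lower number that less compound is needed. Of the compounds shown here, three on a shared core have numbers so far: compound 1 (`CC(C)NCC(=O)NCC(=O)N(C)c1ccc(Cl)cc1C(=O)c1ccccc1Cl`) gives 1 mg/kg, compound 2 (`CC(NC(=O)CN)C(=O)N(C)c1ccc(Cl)cc1C(=O)c1ccccc1Cl`) gives 0.47 mg/kg and compound 3 (`CCC(=O)NCC(=O)N(C)c1ccc(Cl)cc1C(=O)c1ccccc1Cl`) gives 1.4 mg/kg. Compound 3 therefore has two measured neighbours. The nearer comparison is a 1.4-fold higher number from compound 1 to compound 3 (0.15 log units; within the scatter), and the wider one is a 3.0-fold higher number from compound 2 to compound 3 (0.47 log units; beyond the scatter).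

Compound 4 (`CN(C(=O)CNC(=O)c1ccccc1)c1ccc(Cl)cc1C(=O)c1ccccc1Cl`) has not been measured. It carries phenyl in place of ethyl on a carbonyl carbon, which turns propanoylamino into benzamido: phenyl in place of ethyl on a carbonyl carbon.

For the measured compounds named here, no measured step brings a ring into this place, so the read-across is indirect. The closest evidence is methyl in place of isopropylamino on a saturated chain carbon bound to a carbonyl carbon, seen as a 1.4-fold higher number from compound 1 to compound 3 (0.15 log units; within the scatter). The other measured change in that part of the structure, a 2.1-fold lower number from compound 1 to compound 2 (0.33 log units; beyond the scatter), was modest. Neither step gives a direction for the ring, so no shift beyond the scatter is expected in this assay, with wide uncertainty. The estimated change is a 1.1-fold higher number from compound 3 to compound 4 (0.03 log units; within the scatter). For compound 4 the expected value is 1.5 mg/kg, with an estimated range of 0.5 mg/kg to 4.5 mg/kg.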

Compound 4, dose for half-maximal effect: 2.9 mg/kg
Compound 4: middle estimate off by 1.9-fold (0.29 log units), on the low side, and the stated range covers the measured number.
By their numbers in this assay, from the lowest: compound 2; then compounds 1 and 3 (each within the scatter of the next); then compound 4.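

In this assay, for the compounds shown here, phenyl in place of ethyl on a carbonyl carbon gives a 2.1-fold higher number from compound 3 to compound 4 (0.32 log units; beyond the scatter) and is the first measured step that brings a ring into this place, showing that the number here responds to the change from propanoylamino to benzamido, upward and by a modest amount. Compounds 1 and 3 stay within the scatter of each other, whereas compound 4 separates from both, with a 2.9-fold higher number from compound 1 to compound 4 (0.46 log units; beyond the scatter) and a wider gap of a 6.2-fold higher number from compound 2 to compound 4 (0.79 log units; beyond the scatter) that makes compound 4 the highest of the four numbers in this assay and so the compound needing the most for the effect. No measurement on hand accounts for this shift.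

Going by these compounds, one aromatic ring of carbon only is a single example, so it remains open whether cyclohexyl, a pyridine ring or a benzoyl group carrying an amine at this place would follow phenyl or stay closer to ethyl. On these data alone, it also remains open whether phenyl in place of ethyl would give a similar step on the side chain of compound 2, which holds the lowest number so far.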